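Methoxy to Trifluoromethyl: Expecting Another Limit

The source may hold more compounds than are shown below. What is called first, only, known or untested is meant among the compounds shown, and "the series" means these compounds.

Compound 1, `C=C1C[C@]23C[C@@]1(O)CC[C@H]2c1ccc(OS(=O)(=O)c2ccc(C)cc2)c(C)c1[C@@H]3Cn1cc(-c2ccc(OC)cc2)nn1`, gives > 20000 nM in a functional assay on MCF7 cells (Homo sapiens) for cytotoxicity, read by MTT assay, with a stated time of 4 days (a lower number here means a stronger inhibitor, a higher number a weaker inhibitor), which is a limit of the assay and not a number.
Compound 2, `C=C1C[C@]23C[C@@]1(O)CC[C@H]2c1cc(Br)c(O)c(C)c1[C@@H]3Cn1cc(-c2ccccn2)nn1`, gives > 20000 nM in this assay, again a limit.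
Compound 3, `C=C1C[C@]23C[C@@]1(O)CC[C@H]2c1ccc(O)c(C)c1[C@@H]3Cn1cc(-c2ccc(OC)cc2)nn1`, gives > 20000 nM in this assay, again a limit.

Compound 1 therefore stands at the limit, as do the other two measured compounds; none of the three has a readable number, so no ordering among them can be drawn. The unmeasured compound 4, `C=C1C[C@]23C[C@@]1(O)CC[C@H]2c1ccc(OS(=O)(=O)c2ccc(C)cc2)c(C)c1[C@@H]3Cn1cc(-c2ccc(C(F)(F)F)cc2)nn1`, differs from compound 1 in one place: trifluoromethyl in place of methoxy on an aromatic carbon.

Within the data shown here, only one measured step resembles a single change on compound 1, and it is a step that the two limits leave unreadable from compound 1 to compound 3, so it gives no size to lean on. Among the measured compounds shown here, no step is recorded for compound 2 against the others.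

For the measured compounds named here, because the limit of > 20000 nM in this assay, at which 3 of the 3 values shown sit, holds for every value so far, compound 4 is expected to sit at that same limit, with a step that the limit leaves unreadable from compound 1 to compound 4 expected from compound 1 to compound 4, meaning no change beyond the scatter that can be seen. The estimate for compound 4 in this assay is 30000 nM, within a range from 15000 nM to 100000 nM.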

Compound 4, half-maximal inhibitory concentration: > 20000 nM
Compound 4: a limit, no number; the forecaster's own chance of this, stated with the estimate: 85%; the middle value lies beyond the limit too.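

Compound 1 and compound 4 each give only a limit, so the step between them cannot be read and no size can be given for trifluoromethyl in place of methoxy. The compounds shown leave open whether any change to the shared core would give a readable number, because every result so far is the same: the limit of > 20000 nM in this assay, at which 4 of the 4 values shown sit.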